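The compounds below may be only part of what the source reports. "The series", "measured", "known", "first", "only" and "open" are said of these compounds alone.

In a functional assay (mast cells) for inhibition, with Rattus norvegicus as the target (on this read-out lower numbers stand for an effect already at smaller amounts and higher numbers for an effect only at larger amounts of compound), compound 1 `CC1CC/C(=N\Nc2ccccc2F)c2ncc(C(=O)O)c(=O)n21` gives 1200 nM, compound 2 `CC1CC/C(=N\Nc2ccc(Br)cc2)c2ncc(C(=O)O)c(=O)n21` gives 2000 nM, and compound 3 `CCOc1ccc(N/N=C2\CCC(C)n3c2ncc(C(=O)O)c3=O)cc1` gives 17600 nM, the highest of the three numbers. Compound 4 `Cc1ccc(N/N=C2\CCC(C)n3c2ncc(C(=O)O)c3=O)cc1` is not yet measured. It has methyl in place of ethoxy on an aromatic carbon, para to a large group (methyl in place of ethoxy on an aromatic carbon). The measured step closest to this change is an 8.8-fold higher number from compound 2 to compound 3 (0.94 log units; beyond the scatter), with ethoxy in place of bromo. The other, a 1.7-fold higher number from compound 1 to compound 2 (0.22 log units; within the scatter), involves no ethoxy and says little here. Losing ethoxy should therefore lower the number, though no methyl compound has been measured. The expected change is a 4.4-fold lower number from compound 3 to compound 4 (0.64 log units; beyond the scatter). Compound 4 is estimated at 4000 nM, with an expected range from 1500 nM to 12000 nM.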

Compound 4, half-maximal effective concentration: 280 nM
The estimate for compound 4 lay 14-fold (1.15 log units) above the measured number, outside the stated range (below it).
By their numbers in this assay, from the lowest: compound 4; then compounds 1 and 2 (each within the scatter of the next); then compound 3.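

At this place, on an aromatic carbon para to a large group, methyl gives the lowest number of the four in this assay, with a 63-fold lower number from compound 3 to compound 4 (1.80 log units; beyond the scatter) and a 7.1-fold lower number from compound 2 to compound 4 (0.85 log units; beyond the scatter). Among these compounds, the step to the 2-fluorophenyl compound, a 4.3-fold lower number from compound 1 to compound 4 (0.63 log units; beyond the scatter), also lies beyond the scatter, so this position can do more than the earlier compounds showed. No measurement shown explains the size of these steps. The compounds shown leave open whether methoxy or ethyl here would stay near methyl or move towards ethoxy, and whether methyl at another ring carbon would give a similar number.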